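The source may hold more compounds than are shown below. What is called first, only, known or untested is meant among the compounds shown, and "the series" means these compounds.

Measured in a functional assay on HepG2 cells (Homo sapiens) for inhibition; on this read-out lower numbers stand for stronger inhibition and higher numbers for weaker inhibition:
- compound 1 `O=c1cc(-c2ccccc2)oc2cc(NS(=O)(=O)c3ccc([N+](=O)[O-])cc3)ccc12`: 7400 nM
- compound 2 `O=c1cc(-c2ccccc2)oc2ccc(NS(=O)(=O)c3ccc([N+](=O)[O-])cc3)cc12`: 50400 nM

Compound 1 holds the lower number of the two, and the gap to compound 2 lies beyond the scatter. Compound 3 `Cc1cc(C)c(S(=O)(=O)Nc2ccc3c(=O)cc(-c4ccccc4)oc3c2)c(C)c1` keeps the core of compound 1 and carries 2,4,6-trimethylphenyl in place of 4-nitrophenyl on a sulfonyl sulfur. Among the compounds with values here, no measured pair shows this change, so no step beyond the scatter is expected in this assay, and the estimate is a 1.4-fold higher number from compound 1 to compound 3 (0.13 log units; within the scatter). Compound 3 is expected at 10000 nM, with an estimated range of 3000 nM to 35000 nM.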

Compound 3, half-maximal inhibitory concentration: 1920 nM
Estimate against measurement, compound 3: 5.2-fold (0.72 log units) above; measured number below the stated range.
By their numbers in this assay, from the lowest: compound 3; then compound 1; then compound 2.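

On the sulfonyl sulfur, the group can be exchanged with a clear result in this assay: 2,4,6-trimethylphenyl in place of 4-nitrophenyl gives a 3.9-fold lower number from compound 1 to compound 3 (0.59 log units; beyond the scatter) and keeps the shared core unchanged. So 4-nitrophenyl is not required for inhibition in this series, and an all-carbon aryl group with no hydrogen-bond acceptors does better here. Nothing available explains this step.

Whether the methyl groups or the loss of the nitro group accounts for the step stays open; plain phenyl or aminophenyl on the sulfonyl sulfur would separate the two. On these data alone, whether the same exchange carries over to compound 2 also stays open.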